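The source may report more compounds than this note shows. Statements on the series, on what has been measured and on what is new or still open speak of the compounds shown alone.

Measured compounds:
compound 1, `CCOc1cc(C#N)cc(OCC)c1Oc1nc(Nc2ccc(C#N)cc2)nc2ccccc12`, giving 108000 nM in an ADME assay on MT4 cells (Homo sapiens) for cytotoxicity, read by MTT assay, with a stated time of 4 days; on this read-out lower numbers stand for higher toxicity in this test and higher numbers for lower toxicity in this test;
compound 2, `COc1ccc(Oc2nc(Nc3ccc(C#N)cc3)nc3ccccc23)cc1`, giving 340000 nM in this assay;
compound 3, `CCCOc1cc(C#N)cc(OCC)c1Oc1nc(Nc2ccc(C#N)cc2)nc2ccccc12`, giving 123000 nM in this assay.

Compound 2 stands at the highest of the three numbers, so it is the least toxic compound measured here; compound 3 gives a lower number than compound 2, and compound 1 gives a lower number still, both gaps lying beyond the scatter.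

Compound 4, `Cc1cc(C#N)cc(C)c1Oc1nc(Nc2ccc(C#N)cc2)nc2ccccc12`, differs from compound 2 in one place: 4-cyano-2,6-dimethylphenyl in place of 4-methoxyphenyl on an oxygen on an aromatic ring. Among the compounds with values here, no measured step covers this exchange. Within the data shown here, the only measured step, a 1.1-fold higher number from compound 1 to compound 3 (0.06 log units; within the scatter), concerns the length of an alkoxy chain and lies within the scatter, so it says nothing about the group on the oxygen. What the numbers do show is that compound 1 and compound 3, which both carry a 4-cyano-2,6-disubstituted phenyl on that oxygen, give lower numbers than compound 2. On that basis a step downward beyond the scatter is expected, a 2.8-fold lower number from compound 2 to compound 4 (0.45 log units; beyond the scatter).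

Compound 4 is therefore estimated at 120000 nM in this assay, with a range from 50000 nM to 300000 nM.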

Compound 4, half-maximal cytotoxic concentration: 203000 nM
Beside the measured number, compound 4's estimate is 1.7-fold (0.23 log units) below it; low and high end bracket the measured number.
By their numbers in this assay, from the lowest: compounds 1, 3, 4 and 2 (each within the scatter of the next, the first and the last beyond it).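

In this assay the exchange of the whole group on this oxygen comes out as a 1.7-fold lower number from compound 2 to compound 4 (0.22 log units; within the scatter), so compound 2 and compound 4 cannot be told apart on this read-out. The only other step among these compounds concerns a single methyl on an alkoxy chain, so this is the one result that speaks to replacing the aromatic group itself. It shows that 4-cyano-2,6-dimethylphenyl, with 10 heavy atoms against 8 and a nitrile that 4-methoxyphenyl lacks, can stand in place of 4-methoxyphenyl here without a step beyond the scatter, and no measurement shown offers any explanation for this result.

The nitrile and the two methyl groups enter together, so the compounds shown do not separate their shares; a phenyl ring carrying only the nitrile, or only the two methyl groups, on the same oxygen would be needed for that. Also open, from the compounds shown here alone, is whether a group of a different kind on that ring, such as an amine or a carboxylic acid, would likewise stay within the scatter.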